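This account rests on a few compounds, and the source may have more. Where it says the series, first, only, none or still open, it means among the compounds named here.

Compound 1, `CCCCCCCCC(=O)N1c2ccccc2CCC1C(=O)Nc1ccccc1C(F)(F)F`: in a functional assay on PC-3 cells (Homo sapiens) for cytotoxicity, read by sulforhodamine B assay, with a stated time of 72 h (on this read-out lower numbers stand for stronger inhibition of growth and higher numbers for weaker inhibition of growth), compound 1 gives 4320 nM.
Compound 2, `CC(=O)N1c2ccccc2CCC1C(=O)Nc1cc(C(F)(F)F)cc(C(F)(F)F)c1`: compound 2 gives > 70000 nM, which is a limit of the assay rather than a number.
Compound 3, `O=C(Nc1ccccc1C(F)(F)F)C1CCc2ccccc2N1`: compound 3 gives 53300 nM.

Compound 2 therefore sits at the limit of > 70000 nM in this assay, at which 1 of the 3 values shown sits, so only a bound is known for it, and its true value may lie anywhere beyond that bound. Compound 4, `CCCC(=O)N1c2ccccc2CCC1C(=O)Nc1cc(C(F)(F)F)cc(C(F)(F)F)c1`, has not been measured. It differs from compound 2 in one place: ethyl in place of hydrogen on a saturated chain carbon bound to a carbonyl carbon. The acyl group on the ring nitrogen is thus made longer by two carbons.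

One measured step speaks to the role of that acyl group. a 12-fold higher number from compound 1 to compound 3 (1.09 log units; beyond the scatter): taking the octylcarbonyl away altogether gave a clearly weaker compound. The change from compound 2 to compound 4 runs the other way, adding chain rather than removing it, though it adds only ethyl and starts from an acetyl group, not from hydrogen. A lower number, that is stronger growth inhibition, is the expected direction, but the size is uncertain, since compound 2 itself is only known as a limit.

Compound 4 is expected to give about 30000 nM, within 8000 nM to 70000 nM. The expected step is an at least 2.3-fold lower number from compound 2 to compound 4 (0.36 log units; beyond the scatter).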

Compound 4, concentration for 50% growth inhibition: 18600 nM
For compound 4 the middle estimate is 1.6-fold (0.21 log units) above the measured one, within the range that was stated.
By their numbers in this assay, from the lowest: compound 1; then compound 4; then compound 3. At a limit, above all of these: compound 2.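

Lengthening acetyl to propylcarbonyl, with ethyl in place of hydrogen on a saturated chain carbon bound to a carbonyl carbon, gives an at least 3.7-fold lower number from compound 2 to compound 4 (0.57 log units; beyond the scatter) in this assay, so a small change within the acyl group can already move the number beyond the scatter. Compound 2 has only a limit, so the true size of this step remains unknown, and it may be larger than the printed figure: the limit of > 70000 nM in this assay, at which 1 of the 4 values shown sits.

The earlier step, a 12-fold higher number from compound 1 to compound 3 (1.09 log units; beyond the scatter), showed only what happens when the whole octylcarbonyl group is lost, whereas the new step shows that adding a short stretch of chain to an acyl group already in place also goes with stronger inhibition of growth, here on compounds with a different trifluoromethyl substitution.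

The compounds shown leave open whether a longer chain, such as octylcarbonyl on the core of compound 4, would lower the number further or whether the gain would level off. They also leave open whether a branched chain such as isobutyryl, or a chain ending in an amine or a carboxylic acid, would be tolerated at this carbon.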